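From carbamoyl to 2-phenylethenyl at a limit

The source may hold more compounds than are shown below. What is called first, only, known or untested is meant among the compounds shown, and "the series" means these compounds.

Compound 1 `C=C[C@@](C)(/C=C/c1ccc(O)c(/C=C/C#N)c1)CCC=C(C)C` and compound 2 `C=C[C@@](C)(/C=C/c1ccc(O)c(/C=C/C(N)=O)c1)CCC=C(C)C` were both tested in a functional assay on SEM cells (Homo sapiens) for cytotoxicity, with a stated time of 72 h; on this read-out higher numbers stand for an effect only at larger amounts of compound and lower numbers for an effect already at smaller amounts. Compound 1 gives > 36600 nM, which is a limit of the assay and not a number. Compound 2 gives > 36600 nM, which is also only a limit. Compound 2 therefore stands at the limit of > 36600 nM in this assay, at which 2 of the 2 values shown sit. Compound 3 `C=C[C@@](C)(/C=C/c1ccc(O)c(/C=C/C=C/c2ccccc2)c1)CCC=C(C)C` keeps the shared core and changes the same place: 2-phenylethenyl in place of carbamoyl on a double-bonded chain carbon bound to a double-bonded chain carbon. Among the measured compounds shown here, the only measured step at this place is a step that the two limits leave unreadable from compound 1 to compound 2, so it offers no size and no direction to carry over. With so little to go on, only a cautious expectation is possible, and another limit is quite likely. The expected change is an at least 1.4-fold lower number from compound 2 to compound 3 (0.16 log units; that floor lies within the scatter), a modest shift towards smaller amounts at best. Compound 3 is estimated at 25000 nM, with an expected range from 6000 nM to 50000 nM.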

Compound 3, half-maximal effective concentration: > 15000 nM
Compound 3 was reported as a limit; the forecaster's own chance of this, stated with the estimate: 60%; the middle value does not contradict the limit.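

Among the compounds shown here, compound 1, compound 2 and compound 3 each carry only a limit and not a number, and no step among them can be read. On these data alone, whether cyano, carbamoyl and 2-phenylethenyl differ at all in effect at this place stays open, as does the size of any difference.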